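Styryl Sulfonamides Against K562 Cells: A Glycine Substitution

The compounds below may be only part of what the source reports. "The series", "measured", "known", "first", "only" and "open" are said of these compounds alone.

Measured so far:
compound 1 `COc1ccc(/C=C/S(=O)(=O)Nc2ccc(OC)c(F)c2)cc1`: 1000 nM
compound 2 `COc1cc(OC)c(/C=C/S(=O)(=O)Nc2ccc(OC)c(F)c2)c(OC)c1`: 75 nM
compound 3 `COc1cc(OC)c(/C=C/S(=O)(=O)Nc2ccc(F)c([N+](=O)[O-])c2)c(OC)c1`: 75000 nM

In a functional assay on K562 cells (Homo sapiens) for cytotoxicity, read by trypan blue exclusion, with a stated time of 96 h (on this read-out higher numbers stand for weaker inhibition and lower numbers for stronger inhibition), compound 2 holds the lowest of the three numbers. Compound 1 gives a higher number, and compound 3 a far higher one; both gaps lie beyond the scatter. Compound 4 `COc1cc(OC)c(/C=C/S(=O)(=O)Nc2ccc(OC)c(NCC(=O)O)c2)c(OC)c1` differs from compound 2 in one place: (carboxymethyl)amino in place of fluoro on an aromatic carbon. Within the data shown here, no pair of measured compounds shows this change, so the expectation rests on compound 2 alone. The step is expected to be small and toward a somewhat higher number, a 2.0-fold higher number from compound 2 to compound 4 (0.30 log units; within the scatter), since nothing measured here shows what the (carboxymethyl)amino group does. For compound 4 in this assay a value of 150 nM is estimated, within a range from 40 nM to 700 nM.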

Compound 4, half-maximal inhibitory concentration: 20 nM
Compound 4: the middle estimate sits 7.5-fold (0.88 log units) above what was measured; measured number outside the range, below it.
By their numbers in this assay, from the lowest: compound 4; then compound 2; then compound 1; then compound 3.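

In this assay, the aromatic carbon ortho to a methoxy group accepts far more than a single fluorine: (carboxymethyl)amino in place of fluoro, with 5 heavy atoms entering for 1, gives a 3.8-fold lower number from compound 2 to compound 4 (0.57 log units; beyond the scatter). The larger group thus brings no loss on this core, and the number moves downward. Nothing available explains this step. Still open, from the compounds shown here alone, is how a plain amine, a methyl ester of the carboxylic acid or a longer chain on this carbon would compare. Going by these compounds, whether the step would carry over to the core of compound 1 also stays open.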